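Fluoropyridine in place of methylpyridine on the chain

The source may hold more compounds than are shown below. What is called first, only, known or untested is meant among the compounds shown, and "the series" means these compounds.

In an in vitro ADME assay on microsomes from liver (Simiiformes) (on this read-out higher numbers stand for a longer-lived compound and lower numbers for a shorter-lived compound), compound 2 `Cc1ccc(CCCOc2c(C)cc(-c3noc(C)n3)cc2C)cn1` stands highest of the two numbers at 1.37 h against compound 1 `CC(=O)c1ccc(CCCOc2c(C)cc(-c3noc(C)n3)cc2C)o1` at 0.617 h so far. The change leading from compound 2 to compound 3 `Cc1nc(-c2cc(C)c(OCCCc3cccc(F)n3)c(C)c2)no1` is 6-fluoropyridin-2-yl in place of 6-methylpyridin-3-yl on a saturated chain carbon, three bonds along the chain from an oxygen on an aromatic ring and the rest of the structure stays the same. For the measured compounds named here, the only measured step at this place is a 2.2-fold higher number from compound 1 to compound 2 (0.35 log units; beyond the scatter) and it involves a different group, so it sets no direction here. In this assay the expected 1.1-fold higher number from compound 2 to compound 3 (0.04 log units; within the scatter) stays within the scatter. Compound 3 is expected at 1.5 h with an estimated range of 0.7 h to 3.2 h for now.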

Compound 3, half-life: 0.283 h
Compound 3: the middle estimate sits 5.3-fold (0.72 log units) above what was measured, outside the stated range (below it).
By their numbers in this assay, from the lowest: compound 3; then compound 1; then compound 2.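

In this assay this place on the chain proves sensitive even to an exchange of one pyridine for another: 6-fluoropyridin-2-yl in place of 6-methylpyridin-3-yl gives a 4.8-fold lower number from compound 2 to compound 3 (0.68 log units; beyond the scatter) with the count of heavy atoms unchanged. Against 5-acetylfuran-2-yl the same group gives a 2.2-fold lower number from compound 1 to compound 3 (0.34 log units; beyond the scatter) so 6-fluoropyridin-2-yl has the lowest number of the three groups at this place. Nothing available bears on why the number falls.

As far as these compounds go, the step changes the fluorine, the methyl and the point of attachment together, so which of them goes with the lower number stays open. From the compounds shown here alone, how an amine on the pyridine or a longer chain would fare also remains open.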